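Swapping 3-hydroxyphenyl for 2-methylphenyl in a flat series

This account rests on a few compounds, and the source may have more. Where it says the series, first, only, none or still open, it means among the compounds named here.

Of the compounds shown here, three that share one core have been measured so far in a functional assay on PANC-1 cells (Homo sapiens) for inhibition, read by MTT assay, with a stated time of 24 h (a lower number here means a stronger inhibitor, a higher number a weaker inhibitor), and their values sit close together. Compound 1 `CC1(C)[C@H]2CC[C@]1(C)N(Cc1cn(-c3ccccc3Cl)nn1)C(=O)C2` carries 2-chlorophenyl and gives 270 nM as its value. Compound 2 `CC1(C)[C@H]2CC[C@]1(C)N(Cc1cn(-c3cccc(Cl)c3)nn1)C(=O)C2` carries 3-chlorophenyl and gives 260 nM as its value. Compound 3 `CC1(C)[C@H]2CC[C@]1(C)N(Cc1cn(-c3cccc(O)c3)nn1)C(=O)C2` carries 3-hydroxyphenyl and gives 280 nM as its value, which places it level with the other two within the scatter of repeat measurements.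

Compound 4 `Cc1ccccc1-n1cc(CN2C(=O)C[C@@H]3CC[C@@]2(C)C3(C)C)nn1` keeps the core and changes one group. The change is 2-methylphenyl in place of 3-hydroxyphenyl on an aromatic nitrogen and in short it puts 2-methylphenyl in place of 3-hydroxyphenyl on an aromatic nitrogen.

Among the compounds with values here, three measured steps bear on this. Changing 2-chlorophenyl to 3-chlorophenyl gave a 1.0-fold lower number from compound 1 to compound 2 (0.02 log units; within the scatter) and changing 2-chlorophenyl to 3-hydroxyphenyl gave a 1.0-fold higher number from compound 1 to compound 3 (0.02 log units; within the scatter) while hydroxy in place of chloro gave a 1.1-fold higher number from compound 2 to compound 3 (0.03 log units; within the scatter) and all of these lie within the scatter. Within the data shown here, no measured pair swaps hydroxy for methyl, so the expectation rests only on these small steps. In this assay no step beyond the scatter is therefore expected. The estimate amounts to a 1.0-fold lower number from compound 3 to compound 4 (0.02 log units; within the scatter) as the expected step. For compound 4 the estimated value is 270 nM with an expected range from 140 nM to 520 nM as its upper end.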

Compound 4, half-maximal inhibitory concentration: 250 nM
Estimate against measurement, compound 4: 1.1-fold (0.03 log units) above; the measured number falls inside the stated range.
By their numbers in this assay, from the lowest: compounds 4, 2, 1 and 3 (each within the scatter of the next).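

In this assay, the group on the aromatic nitrogen can lose the hydrogen-bond donor and acceptor counted for 3-hydroxyphenyl and become 2-methylphenyl, with its count of 0 for both, and the result is still only a 1.1-fold lower number from compound 3 to compound 4 (0.05 log units; within the scatter). Compounds 1, 2 and 3 all carried a chloro or hydroxy group on the phenyl ring, whereas compound 4 shows that a group made of carbon alone stays level with them: putting methyl in place of chloro gives a 1.1-fold lower number from compound 1 to compound 4 (0.03 log units; within the scatter), and moving from 3-chlorophenyl to 2-methylphenyl gives a 1.0-fold lower number from compound 2 to compound 4 (0.02 log units; within the scatter). Nothing shown here offers any explanation for why these four values stay so close.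

The compounds shown leave open whether any group on this phenyl ring can produce a step beyond the scatter, for example an amine, a carboxylic acid or a longer chain in place of the methyl. They also leave open whether the flat picture holds on a different core, since all four compounds share the same one.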